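Pairing two substituent changes on a shared quinoline-ether amide core

A few compounds are considered here, and "the series" means these few. Any claim that something is new, unique, unknown or untested is made for them only; others in the source may bear on it.

Compound 1 `COc1cc2c(Oc3ccc(NC(=O)c4cn(-c5ccccc5OC(F)(F)F)cn4)cc3F)ccnc2cc1OCCCN1CCCCC1` serves as the reference here. In a functional assay on HT-29 cells (Homo sapiens) for cytotoxicity, read by MTT assay, with a stated time of 72 h (on this read-out higher numbers stand for weaker inhibition and lower numbers for stronger inhibition), compound 1 gives 250 nM. Compound 2 `COc1cc2c(Oc3ccc(NC(=O)c4cn(-c5cc(C)ccc5C)cn4)cc3F)ccnc2cc1OCCCN1CCCCC1` differs from it by 2,5-dimethylphenyl in place of 2-(trifluoromethoxy)phenyl on an aromatic nitrogen, and in this assay compound 2 gives 580 nM; that exchange produced a 2.3-fold higher number from compound 1 to compound 2 (0.37 log units; beyond the scatter). Compound 3 `COc1cc2c(Oc3ccc(NC(=O)c4cn(-c5ccccc5OC(F)(F)F)cn4)cc3F)ccnc2cc1OCCCN1CCC(C)CC1` carries a different core, set apart from that of compound 1 by methyl in place of hydrogen on a saturated ring carbon, and in this assay compound 3 gives 690 nM, so the change gave a 2.8-fold higher number from compound 1 to compound 3 (0.44 log units; beyond the scatter). The values of compound 2 and compound 3 lie within the usual scatter of one another, so no order between them is claimed.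

Compound 4 `COc1cc2c(Oc3ccc(NC(=O)c4cn(-c5cc(C)ccc5C)cn4)cc3F)ccnc2cc1OCCCN1CCC(C)CC1` has not yet been measured. It differs from compound 3 by 2,5-dimethylphenyl in place of 2-(trifluoromethoxy)phenyl on an aromatic nitrogen, the same change that carried compound 1 to compound 2, made here on the core of compound 3. Because the earlier exchange gave a 2.3-fold higher number from compound 1 to compound 2 (0.37 log units; beyond the scatter), the step from compound 3 to compound 4 is expected to be about a 2.3-fold higher number from compound 3 to compound 4 (0.37 log units; beyond the scatter). On that basis compound 4 is estimated to give 1600 nM in this assay, with a plausible range from 800 nM to 3200 nM.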

Compound 4, half-maximal inhibitory concentration: 2220 nM
For compound 4 the middle estimate is 1.4-fold (0.14 log units) below the measured one, within the range that was stated.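

On the core of compound 3, 2,5-dimethylphenyl in place of 2-(trifluoromethoxy)phenyl gave a 3.2-fold higher number from compound 3 to compound 4 (0.51 log units; beyond the scatter) in this assay and this step agrees with its earlier counterpart: the same change on two cores in this assay, a 2.3-fold higher number (0.37 log units; beyond the scatter) from compound 1 to compound 2 and a 3.2-fold higher number (0.51 log units; beyond the scatter) from compound 3 to compound 4, 1.4-fold (0.14 log units) apart, within the scatter of two such steps. Methyl in place of hydrogen on a saturated ring carbon, carried onto the core of compound 2, gave a 3.8-fold higher number from compound 2 to compound 4 (0.58 log units; beyond the scatter) and it also kept its size: the same change on two cores in this assay, a 2.8-fold higher number (0.44 log units; beyond the scatter) from compound 1 to compound 3 and a 3.8-fold higher number (0.58 log units; beyond the scatter) from compound 2 to compound 4, 1.4-fold (0.14 log units) apart, within the scatter of two such steps. Within these four compounds each change therefore carries from one core to the other with no difference beyond the scatter, but two cores per change cannot show that this holds across the series, and the steps do not explain why either change raises the number.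

The compounds shown leave open whether the same holds for a phenyl bearing a nitrile or a carboxylic acid on the aromatic nitrogen, or for a longer chain in place of the methyl on the saturated ring carbon. Whether the steps keep their size in any read-out other than this assay is also an open question.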